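A few compounds are considered here, and "the series" means these few. Any claim that something is new, unique, unknown or untested is made for them only; others in the source may bear on it.

Measured compounds:
- compound 1, `c1cnc2c(c1)CCC[C@@H]2N(CC1CC1)C[C@H]1Cc2c(cccc2N2CCNCC2)CN1`, 26.7 nM
- compound 2, `CN(C[C@H]1Cc2c(cccc2N2CCN(C3CC3)CC2)CN1)[C@H]1CCCc2cccnc21`, 23.5 nM

Both values come from a functional assay on CCRF-CEM cells for antagonist activity at C-X-C chemokine receptor type 4 (Homo sapiens), read by calcium flux, with stated times of 25 min and 90 s; on this read-out higher numbers stand for weaker inhibition and lower numbers for stronger inhibition. Compound 1 has the highest of the two numbers, but compound 2 lies only a short way beneath it, and that gap is within the scatter of repeated measurements, so the two compounds cannot be told apart on these data.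

Compound 3, `CCCN(C[C@H]1Cc2c(cccc2N2CCNCC2)CN1)[C@H]1CCCc2cccnc21`, is the unmeasured compound that follows from compound 1 by a single change: ethyl in place of cyclopropyl on a saturated chain carbon bound to an amine nitrogen. The alkyl arm on the amine nitrogen of compound 1 is thus exchanged for a chain of similar length without the ring. Going by the values given here, no measured pair shows this change, so there is no direct guide to its effect. The two measured compounds, which differ in several places at once, sit at nearly the same level, which suggests the assay tolerates some variation around this amine.

For compound 3 the expectation is therefore a step from compound 1 of a 1.1-fold higher number from compound 1 to compound 3 (0.05 log units; within the scatter), which is no more than the scatter in either direction. The estimated value for compound 3 in this assay is 30 nM, with a range from 12 nM to 75 nM.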

Compound 3, half-maximal inhibitory concentration: 32.2 nM
For compound 3 the middle estimate is 1.1-fold (0.03 log units) below the measured one; the measured number falls inside the stated range.
By their numbers in this assay, from the lowest: compounds 2, 1 and 3 (each within the scatter of the next).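

In this assay, replacing cyclopropyl with ethyl on a saturated chain carbon bound to an amine nitrogen gives a 1.2-fold higher number from compound 1 to compound 3 (0.08 log units; within the scatter); cut one bond further out, this is the same as cyclopropylmethyl giving way to propyl. Going by these compounds alone, this is the first direct reading at this position, and it shows that the three-membered carbon ring can be exchanged for an open chain with no difference that these data can separate from ordinary measurement scatter, so on this pair the ring itself is not required to keep inhibition at this level. No supporting measurement is available that could explain why the two groups read alike.

A single pair on a single core cannot show how widely this tolerance extends, or whether the same exchange would read alike on a different parent compound. It also leaves open what a longer chain such as butyl, or an arm ending in an amine or a carboxylic acid, would do at this place, and so where the tolerance for variation in this arm ends.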